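The compounds below may be only part of what the source reports. "The series", "measured", "known", "first", "only" and "open" are said of these compounds alone.

Working notes on the series. Compound 1 `COc1ccc(-c2nc3ccccn3c2NC2CCCCC2)cc1` is the methoxy member; in an assay on membranes from brain for displacement of a labelled ligand from adenosine receptor A1 (Rattus norvegicus) (on this read-out lower numbers stand for stronger inhibition and higher numbers for weaker inhibition), compound 1 gives 7610 nM. Compound 2 `Cc1ccc(-c2nc3ccccn3c2NC2CCCCC2)cc1` carries methyl in its place, and in this assay compound 2 gives 2060 nM. Within the data shown here, compound 3 `Brc1ccc(-c2nc3ccccn3c2NC2CCCCC2)cc1` carries bromo there; in this assay compound 3 gives 3900 nM, the second highest of the three numbers, with a 1.9-fold higher number from compound 2 to compound 3 (0.28 log units; within the scatter) and a 2.0-fold lower number from compound 1 to compound 3 (0.29 log units; within the scatter) both small, while a 3.7-fold lower number from compound 1 to compound 2 (0.57 log units; beyond the scatter) is the only step so far that clears the scatter. Compound 4 `Oc1ccc(-c2nc3ccccn3c2NC2CCCCC2)cc1` is the next member.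

hydroxy in place of bromo on an aromatic carbon

Among the measured compounds shown here, every measured step sits on the same aromatic carbon, yet none brings in hydroxy, so this change has no direct precedent in the set; the three substituents tried so far span only a modest spread in this assay. Because a 2.0-fold lower number from compound 1 to compound 3 (0.29 log units; within the scatter) and a 1.9-fold higher number from compound 2 to compound 3 (0.28 log units; within the scatter) both lie within the scatter, the step of a 1.5-fold higher number from compound 3 to compound 4 (0.19 log units; within the scatter) is expected to stay close to compound 3, if anything on the higher side and not clearly beyond the scatter. Compound 4 is estimated at 6000 nM, with a range of 2000 nM to 18000 nM.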

Compound 4, inhibition constant: 5530 nM
Estimate against measurement, compound 4: 1.1-fold (0.04 log units) above; the measured number falls inside the stated range.
By their numbers in this assay, from the lowest: compounds 2, 3, 4 and 1 (each within the scatter of the next, the first and the last beyond it).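

In this assay, hydroxy on this aromatic carbon, para to a large group, brings in a hydrogen-bond donor, yet the number stays within the scatter of bromo (a 1.4-fold higher number from compound 3 to compound 4 (0.15 log units; within the scatter)) and of methoxy (a 1.4-fold lower number from compound 1 to compound 4 (0.14 log units; within the scatter)). Taking the methyl off the oxygen therefore makes no readable difference here. Against methyl the change does clear the scatter (a 2.7-fold higher number from compound 2 to compound 4 (0.43 log units; beyond the scatter)), so methyl now stands apart from both oxygen-linked substituents, while bromo remains within the scatter of all three.

Going by these compounds, what an amine or a carboxylic acid on this carbon would give stays open, as does whether any group here reaches a number clearly lower than that of compound 2 (2060 nM). No evidence at hand bears on the reason for these differences.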